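A few compounds are considered here, and "the series" means these few. Any claim that something is new, unique, unknown or untested is made for them only; others in the source may bear on it.

Of the compounds shown here, three from one series have been tested in a functional assay on Caco-2 cells (Homo sapiens), read by MTT assay, with a stated time of 48 h; a lower number here means a stronger inhibitor, a higher number a weaker inhibitor. Compound 1 `CC[C@@H](C)[C@H](NC(=O)c1ccc(C(CC)(CC)c2ccc(OCC(=O)C(C)(C)C)c(C)c2)n1CC)C(=O)O` gives 4500 nM. Compound 2 `CCn1c(C(=O)N(C)CC(=O)O)ccc1C(CC)(CC)c1ccc(OCC(=O)C(C)(C)C)c(C)c1` carries (carboxymethyl)(methyl)amino in place of (1-carboxy-2-methylbutyl)amino on a carbonyl carbon and gives 35900 nM, so that change made an 8.0-fold higher number from compound 1 to compound 2 (0.90 log units; beyond the scatter). Compound 3 `CC[C@@H](C)[C@H](NC(=O)c1ccc(C(CC)(CC)c2ccc(OCC(O)C(C)(C)C)c(C)c2)n1CC)C(=O)O` differs from compound 1 in its core by 1-hydroxy-2,2-dimethylpropyl in place of (tert-butyl)carbonyl on a saturated chain carbon bound to an oxygen on an aromatic ring, and in this assay compound 3 gives 3400 nM, a step of a 1.3-fold lower number from compound 1 to compound 3 (0.12 log units; within the scatter). Compound 4 `CCn1c(C(=O)N(C)CC(=O)O)ccc1C(CC)(CC)c1ccc(OCC(O)C(C)(C)C)c(C)c1` has not yet been measured. It differs from compound 3 by (carboxymethyl)(methyl)amino in place of (1-carboxy-2-methylbutyl)amino on a carbonyl carbon, which is the same change that turned compound 1 into compound 2, now made on the core of compound 3; the surroundings of the place are described in the same words both times. For compound 4 in this assay a step of about a 7.9-fold higher number from compound 3 to compound 4 (0.90 log units; beyond the scatter) is expected, resting on the step of an 8.0-fold higher number from compound 1 to compound 2 (0.90 log units; beyond the scatter) that the same change made on the other core, and on the closeness of the two cores shown by compound 1 and compound 3. The estimate for compound 4 is therefore 27000 nM, with a likely range from 12000 nM to 60000 nM.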

Compound 4, half-maximal inhibitory concentration: 31900 nM
The estimate for compound 4 lay 1.2-fold (0.07 log units) below the measured number; low and high end bracket the measured number.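

In this assay, (carboxymethyl)(methyl)amino in place of (1-carboxy-2-methylbutyl)amino on a carbonyl carbon made a 9.4-fold higher number from compound 3 to compound 4 (0.97 log units; beyond the scatter), which matches the step seen on the other core: the same change on two cores in this assay, an 8.0-fold higher number (0.90 log units; beyond the scatter) from compound 1 to compound 2 and a 9.4-fold higher number (0.97 log units; beyond the scatter) from compound 3 to compound 4, 1.2-fold (0.07 log units) apart, within the scatter of two such steps. The other change, 1-hydroxy-2,2-dimethylpropyl in place of (tert-butyl)carbonyl, made a 1.1-fold lower number from compound 2 to compound 4 (0.05 log units; within the scatter), so it also behaved alike on both cores, with no step beyond the scatter on either: the same change on two cores in this assay, a 1.3-fold lower number (0.12 log units; within the scatter) from compound 1 to compound 3 and a 1.1-fold lower number (0.05 log units; within the scatter) from compound 2 to compound 4, 1.2-fold (0.07 log units) apart, within the scatter of two such steps. In these four compounds, then, the effect of each change carried from one core to the other, but this rests on a single pair of cores and a single pair of replacements, so it shows neither a general rule for the series nor the reason for the size of either step.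

The compounds shown leave open whether the same transfer would hold for other groups on the carbonyl carbon, such as a simple amine or a longer chain ending in a carboxylic acid. They also leave open whether it would hold for a group other than the 1-hydroxy-2,2-dimethylpropyl chain, such as a shorter alkyl chain.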